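The source may hold more compounds than are shown below. What is called first, only, known or untested is meant among the compounds shown, and "the series" means these compounds.

Working notes on the series. All compounds share one core and differ at the amine nitrogen whose other neighbour is a double-bonded ring carbon. In a functional assay on HepG2 cells (Homo sapiens) for inhibition, read by MTT assay, with a stated time of 48 h (on this read-out lower numbers stand for stronger inhibition and higher numbers for weaker inhibition), compound 1 `CCOC(=O)C1=C(N/C=N/c2ccccn2)Nc2[nH]nc(C)c2C1c1ccc(N(C)C)cc1` gives 26200 nM; in the same assay compound 2 `CCOC(=O)C1=C(N/N=C(/Cl)C#N)Nc2[nH]nc(C)c2C1c1ccc(N(C)C)cc1` gives 23600 nM, and compound 3 `CCOC(=O)C1=C(N/C=N/c2ccc(C)cc2)Nc2[nH]nc(C)c2C1c1ccc(N(C)C)cc1` gives 44400 nM. Compound 3 holds the highest of the three numbers, but the step of a 1.7-fold higher number from compound 1 to compound 3 (0.23 log units; within the scatter) and the step of a 1.9-fold higher number from compound 2 to compound 3 (0.27 log units; within the scatter) both sit within the scatter, so the three compounds are not separated on this read-out.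

Compound 4 `CCOC(=O)C(=NNC1=C(C(=O)OCC)C(c2ccc(N(C)C)cc2)c2c(C)n[nH]c2N1)C(=O)OCC` is not yet measured. It differs from compound 3 by a group of 12 heavy atoms (7 carbon, 1 nitrogen, 4 oxygen; no ring) in place of a group of 9 heavy atoms (8 carbon, 1 nitrogen; one six-membered aromatic ring of carbon only), on an amine nitrogen. The step that bears most on it is a 1.9-fold higher number from compound 2 to compound 3 (0.27 log units; within the scatter), where a group without a ring was exchanged for the aromatic group at the same amine nitrogen; the step of a 1.1-fold lower number from compound 1 to compound 2 (0.05 log units; within the scatter) likewise exchanged a ring group for a group without a ring at that nitrogen and also stayed within the scatter. Going by the values given here, no measured compound carries a group resembling the one that enters, so the comparison is loose. The number for compound 4 is therefore expected to lie near the three measured values, with the step of a 1.4-fold lower number from compound 3 to compound 4 (0.14 log units; within the scatter) expected to remain within the scatter. Compound 4 is estimated at 32000 nM, in the range 12000 nM to 80000 nM.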

Compound 4, half-maximal inhibitory concentration: 80800 nM
Compound 4: the middle estimate sits 2.5-fold (0.40 log units) below what was measured, and the stated range ends below it.
By their numbers in this assay, from the lowest: compounds 2, 1, 3 and 4 (each within the scatter of the next, the first and the last beyond it).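

The group on the amine nitrogen can shift the number in this assay beyond the scatter, as the series now shows two such steps (a 3.4-fold higher number from compound 2 to compound 4 (0.53 log units; beyond the scatter)) and (a 3.1-fold higher number from compound 1 to compound 4 (0.49 log units; beyond the scatter)), while another remains within it (a 1.8-fold higher number from compound 3 to compound 4 (0.26 log units; within the scatter)). Lack of a ring does not by itself set the result at this position: compound 2 and compound 4 both carry a group without a ring, yet the step that joins them is one of those beyond the scatter, and the group entering in compound 4 has no ring, 3 double bonds outside aromatic rings and 5 hydrogen-bond acceptors. Nothing at hand accounts for the size of these steps.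

Going by these compounds, it remains open whether the higher number follows the entering group as a whole or only one part of it, and how a carboxylic acid or a simple alkyl amine would read at this amine nitrogen. On these data alone, it also remains open whether the 4-methylphenyl-bearing group of compound 3 and the group of compound 4 can be told apart in this assay at all.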